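This account rests on a few compounds, and the source may have more. Where it says the series, first, only, none or still open, it means among the compounds named here.

Working notes on the series. In an ADME assay on HEK-293T cells (Homo sapiens) for cytotoxicity, read by CCK-8 assay, with a stated time of 48 h (a lower number here means that less compound is tolerated, a higher number that more compound is tolerated), compound 1 `Cn1cc(SCC(=O)Nc2ccccc2Cl)c2ccccc21` reaches only the limit of > 100000 nM, which is a limit and not a number (the limit of > 100000 nM in this assay, at which 1 of the 3 values shown sits). Compound 2 `O=C(CSc1c[nH]c2ccc(Cl)cc12)Nc1ccc(Cl)c(Cl)c1` gives 42700 nM in this assay. Compound 3 `O=C(CSc1c[nH]c2cccc(Cl)c12)Nc1ccc(Cl)c(Cl)c1` gives 34700 nM in this assay, the lowest of the two numbers in hand, with compound 2 as its nearest neighbour within the scatter. Compound 4 `COc1cccc2[nH]cc(SCC(=O)Nc3ccc(Cl)c(Cl)c3)c12` has not yet been measured in this assay; it differs from compound 3 by methoxy in place of chloro on an aromatic carbon. Going by the values given here, no step between measured compounds is available to calibrate this change, so no shift beyond the scatter is expected, and the step from compound 3 to compound 4 in this assay is estimated at a 1.4-fold higher number from compound 3 to compound 4 (0.16 log units; within the scatter). For compound 4 the expected value in this assay is 50000 nM, with a range of 22000 nM to 110000 nM.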

Compound 4, half-maximal cytotoxic concentration: > 100000 nM
Compound 4 gave a limit, no number; the forecaster's own chance of this, stated with the estimate: 25%; middle value at least 2.0-fold (0.30 log units) from the limit.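

Methoxy in place of chloro on this aromatic carbon gives the only calibrated step in the series in this assay, and it lies beyond the scatter: an at least 2.8-fold higher number from compound 3 to compound 4 (0.45 log units; beyond the scatter). A single change at this carbon can therefore move the reading out of the range of the two numbers in hand. Compound 4 gives a limit and not a number, so the full size of the step stays unfixed: the limit of > 100000 nM in this assay, at which 2 of the 4 values shown sit.

From the compounds shown here alone, what an amine, a hydroxyl or a longer alkoxy chain on this aromatic carbon would do in this assay remains open.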